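From Nitro to Hydroxy in a Small Series

The compounds below may be only part of what the source reports. "The series", "measured", "known", "first", "only" and "open" are said of these compounds alone.

compound 1 `CCCc1cc(/C=C/C(=O)c2ccc(O)cc2)c(OC)cc1O` gives 41000 nM
compound 2 `COc1cc(/C=C/C(=O)c2ccc([N+](=O)[O-])cc2)cc(OC)c1` gives 20000 nM
compound 3 `COc1cc(/C=C/C(=O)c2ccc(OC)c(OC)c2OC)cc(OC)c1` gives 8700 nM

All three were tested in a functional assay (Homo sapiens) for inhibition; on this read-out lower numbers stand for stronger inhibition and higher numbers for weaker inhibition. On these numbers, compound 2 stands second highest of the three, with compound 1 above it and compound 3 below it, and both gaps lie beyond the scatter. Compound 4 `COc1cc(/C=C/C(=O)c2ccc(O)cc2)cc(OC)c1` has not yet been measured. It carries hydroxy in place of nitro on an aromatic carbon, para to a large group: hydroxy in place of nitro on an aromatic carbon. Going by the values given here, no measured pair isolates this change, so its size cannot be read directly. Compound 1, which also carries hydroxy in that place, gives 41000 nM, the nearest number to that of compound 2, though it differs from compound 4 elsewhere too. In this assay, no step beyond the scatter is therefore expected, with a slight lean toward weaker inhibition. The expected change is a 1.3-fold higher number from compound 2 to compound 4 (0.10 log units; within the scatter). For compound 4 the estimated value is 25000 nM, with an expected range from 8000 nM to 70000 nM.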

Compound 4, half-maximal inhibitory concentration: 14000 nM
Beside the measured number, compound 4's estimate is 1.8-fold (0.25 log units) above it; the measured number falls inside the stated range.
By their numbers in this assay, from the lowest: compounds 3, 4 and 2 (each within the scatter of the next, the first and the last beyond it); then compound 1.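

Hydroxy in place of nitro on an aromatic carbon, para to a large group, now has a measured size in this assay and gives a 1.4-fold lower number from compound 2 to compound 4 (0.15 log units; within the scatter) with nothing else in the structure altered. The earlier compounds shown here held no pair that differed in this one place, and this pair shows that nitro and hydroxy cannot be told apart here on this read-out, even though the two groups differ in size and in their hydrogen-bond donors. No measurement shown here offers an account of this result.

Still open, from the compounds shown here alone, is whether an amine or a carboxylic acid on this aromatic carbon would stay within the scatter of compound 2 and compound 4 or move beyond it. A single pair also leaves open whether the same exchange would give a similar step on a different core, such as the core of compound 1.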